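The source may report more compounds than this note shows. Statements on the series, on what has been measured and on what is new or still open speak of the compounds shown alone.

The compounds share one core, seen in compound 1 `C/C(=C\C(=O)Nc1ccccc1OCCCC(=O)O)c1ccc2c(ccn2C)c1`, which in an assay on Prostate gland for inhibition of steroid 5-alpha-reductase (Rattus norvegicus) (on this read-out lower numbers stand for stronger inhibition and higher numbers for weaker inhibition), gives 780 nM. Compound 2 `C/C(=C\C(=O)Nc1ccccc1OCCCC(=O)O)c1ccc2c(ccn2CC(C)C)c1` gives 160 nM in this assay, the second highest of the three numbers measured, while compound 3 `CCCCCC(CCCCC)n1ccc2cc(/C(C)=C/C(=O)Nc3ccccc3OCCCC(=O)O)ccc21` gives 25 nM. Compound 4 `C/C(=C\C(=O)Nc1ccccc1OCCCC(=O)O)c1ccc2c(ccn2Cc2ccc(C)cc2)c1` differs from compound 2 by 4-methylphenyl in place of isopropyl on a saturated chain carbon bound to an aromatic nitrogen. Among the measured compounds shown here, two measured steps bear on it, both enlarging the group on the aromatic nitrogen: a 4.9-fold lower number from compound 1 to compound 2 (0.69 log units; beyond the scatter) and a 6.4-fold lower number from compound 2 to compound 3 (0.81 log units; beyond the scatter), and across the whole span a 31-fold lower number from compound 1 to compound 3 (1.49 log units; beyond the scatter). Because a 4.9-fold lower number from compound 1 to compound 2 (0.69 log units; beyond the scatter) and a 6.4-fold lower number from compound 2 to compound 3 (0.81 log units; beyond the scatter) both lowered the number, a modest further fall is expected for compound 4, estimated as a 2.7-fold lower number from compound 2 to compound 4 (0.43 log units; beyond the scatter). Compound 4 is therefore expected to give about 60 nM in this assay, within a range of 20 nM to 200 nM.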

Compound 4, half-maximal inhibitory concentration: 88 nM
Compound 4: middle estimate off by 1.5-fold (0.17 log units), on the low side; low and high end bracket the measured number.
By their numbers in this assay, from the lowest: compound 3; then compounds 4 and 2 (each within the scatter of the next); then compound 1.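

Replacing isobutyl with 4-methylbenzyl on the aromatic nitrogen brings in an aromatic ring, yet a 1.8-fold lower number from compound 2 to compound 4 (0.26 log units; within the scatter) leaves these two compounds indistinguishable, so this ring does not extend the trend seen with the alkyl groups. The 4-methylbenzyl group still stands well apart from methyl, with an 8.9-fold lower number from compound 1 to compound 4 (0.95 log units; beyond the scatter), but it does not match 1-pentylhexyl, with a 3.5-fold higher number from compound 3 to compound 4 (0.55 log units; beyond the scatter). Nothing measured here explains these differences. The compounds shown leave open how an unsubstituted benzyl, a 4-methoxybenzyl or a straight hexyl chain on that nitrogen would compare.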